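Carbamoyl in place of cyano: an expected half-life

The compounds below may be only part of what the source reports. "The series", "measured", "known", "first", "only" and "open" are said of these compounds alone.

In a physicochemical assay for metabolic stability, read by HPLC, in phosphate buffer, at pH 7.4 (on this read-out lower numbers stand for a shorter-lived compound and higher numbers for a longer-lived compound), compound 1 (`CN(/N=N/c1ccc(C#N)cc1)C(=O)CCc1ccc(O)cc1`) gives 76 h as its half-life. For the measured compounds named here, compound 2 (`CN(/N=N/c1ccc(C#N)cc1)C(=O)CCCCc1ccc(O)cc1`), the only other measured compound, gives 82.5 h as its half-life, and the two numbers lie within the scatter of each other. Compound 3 (`CN(/N=N/c1ccc(C(N)=O)cc1)C(=O)CCc1ccc(O)cc1`) has carbamoyl in place of cyano on an aromatic carbon. Going by the values given here, no measured step shows this exchange in this assay and none beyond the scatter is expected, in either direction. The expected change is a 1.0-fold lower number from compound 1 to compound 3 (0.01 log units; within the scatter) and stays within the scatter. Compound 3 is estimated at 75 h with an expected range of 35 h to 160 h for its half-life.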

Compound 3, half-life: 118 h
Beside the measured number, compound 3's estimate is 1.6-fold (0.20 log units) below it; the measured number falls inside the stated range.
By their numbers in this assay, from the lowest: compounds 1, 2 and 3 (each within the scatter of the next).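

Carbamoyl in place of cyano, on an aromatic carbon para to a large group, gives in this assay a 1.6-fold higher number from compound 1 to compound 3 (0.19 log units; within the scatter). For the compounds shown here, the earlier compounds held cyano throughout, so this is the first reading at this position, and it shows that a group with a hydrogen-bond donor can stand there without a change beyond the scatter. No measurement at hand bears on the reason for this result. As far as these compounds go, whether a carboxylic acid or an amine on that carbon would move the half-life beyond the scatter remains open. So does whether carbamoyl would give a similar result on the core of compound 2.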